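Swapping the halogenated ring on compound 2

The compounds below may be only part of what the source reports. "The series", "measured", "known", "first", "only" and "open" are said of these compounds alone.

Compound 1 `CCOc1ccccc1-c1ccc(-c2nc3cnccc3c(NC(C)C(=O)O)c2C#N)cc1`: 2.1
Compound 2 `CC[C@@H](Nc1c(C#N)c(-c2ccc(-c3cccc(Cl)c3F)cc2)nc2cnccc12)C(N)=O`: 3.1
Compound 3 `CCOc1ccccc1-c1ccc(-c2nc3cnccc3c(N[C@H](CC)C(=O)NS(C)(=O)=O)c2C#N)cc1`: 2.2

In a physicochemical assay for lipophilicity, read by HPLC, at pH 7.5 (on this read-out lower numbers stand for lower lipophilicity and higher numbers for higher lipophilicity), compound 2 sits at the top of the three measured numbers; compound 3 lies below it, and compound 1 lies lowest, both gaps beyond the scatter. For the measured compounds named here, the only single-point step measured so far, a number 0.10 log units higher from compound 1 to compound 3 (within the scatter), concerns the side chain on the ring nitrogen and not the outer aromatic ring, so it gives no direct guide to the change at hand.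

Compound 4 `CC[C@@H](Nc1c(C#N)c(-c2ccc(-c3ccc(Cl)cc3)cc2)nc2cnccc12)C(N)=O` differs from compound 2 in one place: 4-chlorophenyl in place of 3-chloro-2-fluorophenyl on an aromatic carbon. Going by the values given here, no measured pair shows this kind of swap, so the expectation rests on the size of the groups alone. One fewer heavy atom in the entering ring would be expected to leave this assay essentially where compound 2 stands, with at most a small downward shift, so the step of a number 0.20 log units lower from compound 2 to compound 4 (within the scatter) is expected to stay within the scatter. Compound 4 is therefore estimated at 2.9, with a range from 2.5 to 3.3.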

Compound 4, distribution coefficient: 3.1
Compound 4: the middle estimate sits 0.20 log units below what was measured; measured number inside the range.
By their numbers in this assay, from the lowest: compounds 1 and 3 (each within the scatter of the next); then compounds 2 and 4 (each within the scatter of the next).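

For the compounds shown here, the step on the outer ring gives the first reading at this position, an aromatic carbon para to a large group: in this assay, 4-chlorophenyl in place of 3-chloro-2-fluorophenyl gives no change at the digits printed from compound 2 to compound 4 (within the scatter). The earlier step concerned only the side chain on the ring nitrogen, whereas this one shows that these two chlorine-bearing phenyl rings can be exchanged here, with one fewer heavy atom in the entering ring, without a shift beyond the scatter. Nothing shown offers an explanation for this result.

From the compounds shown here alone, the fluorine and the placing of the chlorine change together in this step, so their separate contributions remain open, and a phenyl ring carrying fluorine alone could separate them. Also open, going by these compounds, is how this assay would respond to a group of another kind on this ring, such as an amine or a carboxylic acid.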